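The compounds below may be only part of what the source reports. "The series", "measured", "known", "first", "only" and "open" are said of these compounds alone.

Measured compounds in an assay on HEK293 cells for displacement of a labelled ligand from Melanocortin receptor 4 (Homo sapiens); a lower number here means a stronger inhibitor, a higher number a weaker inhibitor:

compound 1, `COc1cc(CC(C)C(=O)N2CCN(c3ccc(C(F)(F)F)cc3[C@@H](N)CC(C)C)CC2)ccc1Cl`: 230 nM
compound 2, `COc1ccc(OCC(=O)N2CCN(c3ccc(C(F)(F)F)cc3[C@@H](N)CC(C)C)CC2)cc1`: 3800 nM
compound 3, `CC(C)C[C@H](N)c1cc(C(F)(F)F)ccc1N1CCN(C(=O)CCNC2CCCCC2)CC1`: 4800 nM

Compound 1 gives the lowest number of the three, so it is the strongest binder measured here. The other two compounds sit well apart from it: a 17-fold higher number from compound 1 to compound 2 (1.22 log units; beyond the scatter) and a 21-fold higher number from compound 1 to compound 3 (1.32 log units; beyond the scatter), while compound 2 and compound 3 lie close together, a 1.3-fold higher number from compound 2 to compound 3 (0.10 log units; within the scatter).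

Compound 4, `COc1ccc(CC(C)C(=O)N2CCN(c3ccc(C(F)(F)F)cc3[C@@H](N)CC(C)C)CC2)cc1F`, has not yet been measured in this assay. It keeps the whole of compound 1 except for one part of the side chain attached to the carbonyl:

3-fluoro-4-methoxyphenyl in place of 4-chloro-3-methoxyphenyl on a saturated chain carbon, two bonds along the chain from a carbonyl carbon

The two measured steps away from compound 1 both remove the entire 1-(4-chloro-3-methoxybenzyl)ethyl group and put an unrelated chain in its place, and both steps were large. They show that this region of the molecule matters strongly for binding, but neither step swaps one substituted aromatic ring for another of the same size, which is what happens between compound 1 and compound 4. The change is therefore smaller than anything measured, and its direction cannot be read from the measured steps. A modest loss of binding seems the more likely outcome, with a step for compound 4 expected of about a 2.0-fold higher number from compound 1 to compound 4 (0.29 log units; within the scatter). Compound 4 is thus estimated at 450 nM, within a range of 150 nM to 1400 nM.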

Compound 4, inhibition constant: 200 nM
The estimate for compound 4 lay 2.3-fold (0.35 log units) above the measured number; low and high end bracket the measured number.
By their numbers in this assay, from the lowest: compounds 4 and 1 (each within the scatter of the next); then compounds 2 and 3 (each within the scatter of the next).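

In this assay, 3-fluoro-4-methoxyphenyl in place of 4-chloro-3-methoxyphenyl gives a 1.2-fold lower number from compound 1 to compound 4 (0.06 log units; within the scatter) and so the two compounds cannot be told apart, which shows that this position accepts more than one substituted phenyl ring, with fluorine instead of chlorine and a different substitution pattern. The large gaps seen earlier also hold for the new ring, with a 24-fold lower number from compound 3 to compound 4 (1.38 log units; beyond the scatter) and a 19-fold lower number from compound 2 to compound 4 (1.28 log units; beyond the scatter) as the steps from the two compounds with unrelated chains, so the stronger binding in this small set is not tied to the exact ring of compound 1. Nothing in the data explains why these two rings give such similar numbers.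

Both substituents differ in this one swap, so the separate roles of the halogen and of the methoxy group's location remain unresolved. As far as these compounds go, it also remains open whether an unsubstituted phenyl ring, a pyridine ring, or a phenyl ring carrying a nitrile would fit this position equally well, and whether a longer chain between the ring and the carbonyl would be accepted.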